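A few compounds are considered here, and "the series" means these few. Any claim that something is new, unique, unknown or untested is made for them only; others in the source may bear on it.

Measured compounds:
Compound 1 `CCC1=C(C(=O)CCC2CCCC2)[C@H](c2ccc(O)c(Cl)c2)NC(=O)N1` gives > 10000 nM in an ADME assay on cells (Homo sapiens) for cytotoxicity (on this read-out lower numbers stand for higher toxicity in this test and higher numbers for lower toxicity in this test), which is a limit of the test.
Compound 2 `CCC1=C(C(=O)CC2CCC(OC)CC2)[C@H](c2ccc(O)c(Cl)c2)NC(=O)N1` gives > 10000 nM in this assay, also a limit.

Compound 2 thus stands at the limit, where (the limit of > 10000 nM in this assay, at which 2 of the 2 values shown sit). The step that the two limits leave unreadable from compound 1 to compound 2 is accordingly not readable. Compound 3 `CCC1=C(C(=O)CC2CCC(C(C)C)CC2)[C@H](c2ccc(O)c(Cl)c2)NC(=O)N1` differs from compound 2 by isopropyl in place of methoxy on a saturated ring carbon. Going by the values given here, no measured step bears on this change with a readable size, since both values so far are limits. Compound 3 is expected to stay at the limit as well, with an estimated step that the limit leaves unreadable from compound 2 to compound 3 meaning none beyond the scatter. The estimate for compound 3 is 15000 nM, between 5000 nM and 50000 nM.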

Compound 3, half-maximal cytotoxic concentration: > 10000 nM
Compound 3 was reported as a limit; the forecaster's own chance of this, stated with the estimate: 80%; the middle value does not contradict the limit.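

Compound 3 gives > 10000 nM in this assay, which is a limit. No step among compound 1, compound 2 and compound 3 can be read: the limit of > 10000 nM in this assay, at which 3 of the 3 values shown sit.

The compounds shown leave open how much any of these side chains changes toxicity in this assay.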